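A few compounds are considered here, and "the series" means these few. Any claim that something is new, unique, unknown or untested is made for them only; others in the source may bear on it.

The measurements in a functional assay on A549 cells (Homo sapiens) for inhibition, read by MTT assay, with a stated time of 72 h (on this read-out higher numbers stand for weaker inhibition and lower numbers for stronger inhibition), so far cover three compounds:

compound 1, `O=C(CCC(=O)OCCCCCCSc1ccc([N+](=O)[O-])c2nonc12)Nc1ccccc1F`: 2440 nM
compound 2, `O=C(CCC(=O)OCCCCCCSc1ccc([N+](=O)[O-])c2nonc12)Nc1ccccc1Cl`: 2750 nM
compound 3, `COc1ccccc1NC(=O)CCC(=O)OCCCCCCSc1ccc([N+](=O)[O-])c2nonc12`: 1870 nM

Among these three numbers compound 1 stands second highest. Its nearest neighbour is compound 2, with a 1.1-fold higher number from compound 1 to compound 2 (0.05 log units; within the scatter); the furthest is compound 3, with a 1.3-fold lower number from compound 1 to compound 3 (0.12 log units; within the scatter). Compound 2 and compound 3 are separated by a 1.5-fold lower number from compound 2 to compound 3 (0.17 log units; within the scatter). All three steps lie within the scatter, so the three compounds cannot be told apart on this read-out.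

Compound 4, `CN(C)CCNC(=O)CCC(=O)OCCCCCCSc1ccc([N+](=O)[O-])c2nonc12`, is the next compound to be measured. Its difference from compound 1 is 2-(dimethylamino)ethyl in place of 2-fluorophenyl on an amide-type nitrogen.

Going by the values given here, none of the measured steps bears directly on this change: each of them swaps one substituent for another on the aromatic ring that remains in place, whereas compound 4 removes that ring altogether and puts a chain on the amide-type nitrogen in its stead. Among the compounds with values here, the measured steps show only that changes at the ring substituent leave the number within the scatter. Since no comparison of this kind exists, the expectation for compound 4 is anchored on compound 1 with a wide range. Compound 4 is expected to give 3000 nM, between 800 nM and 12000 nM. This estimate corresponds to an expected 1.2-fold higher number from compound 1 to compound 4 (0.09 log units; within the scatter).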

Compound 4, half-maximal inhibitory concentration: 5550 nM
Compound 4: middle estimate off by 1.9-fold (0.27 log units), on the low side, within the range that was stated.
By their numbers in this assay, from the lowest: compounds 3, 1, 2 and 4 (each within the scatter of the next, the first and the last beyond it).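

In this assay, going by these compounds alone, exchanging the whole aromatic group on the amide-type nitrogen for 2-(dimethylamino)ethyl gives the first steps in this set that lie beyond the scatter (a 2.3-fold higher number from compound 1 to compound 4 (0.36 log units; beyond the scatter)) and (a 3.0-fold higher number from compound 3 to compound 4 (0.47 log units; beyond the scatter)), although both are modest and the comparison with the 2-chlorophenyl compound goes against a clean separation (a 2.0-fold higher number from compound 2 to compound 4 (0.30 log units; within the scatter)). The position therefore responds somewhat more to replacing the entire 2-substituted phenyl group than the earlier ring-substituent swaps showed, yet the six-membered aromatic ring can leave without the number moving by more than these modest steps. Nothing measured here accounts for the shift, and the data give no reason for it.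

The compounds shown do not separate the loss of the aromatic ring from the arrival of the dimethylamino group, and a plain hexyl chain, a benzyl group or a 2-hydroxyethyl group on the same nitrogen would bear on that question. They also leave open how the number responds to the length of the chain carrying the amine, as with a 3-(dimethylamino)propyl group, or to a morpholine in place of the dimethylamino group.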